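Hydroxy for methoxy on the aryl substituent

This account rests on a few compounds, and the source may have more. Where it says the series, first, only, none or still open, it means among the compounds named here.

In an assay on HEK293 cells for displacement of a labelled ligand from 5-hydroxytryptamine receptor 7 (Rattus norvegicus), with a stated time of 60 min (on this read-out lower numbers stand for stronger inhibition and higher numbers for weaker inhibition), compound 1 `FC(F)(F)c1ccc(-c2cn(Cc3ccccc3)c3c2CNCC3)cc1` gives 167 nM. In this assay compound 2 `COc1ccc(-c2cn(Cc3ccccc3)c3c2CNCC3)cc1` gives 290 nM; the step of a 1.7-fold higher number from compound 1 to compound 2 (0.24 log units; within the scatter) leaves the two unseparated, so compound 2 carries the larger of the two numbers only within that scatter. Compound 3 `Oc1ccc(-c2cn(Cc3ccccc3)c3c2CNCC3)cc1` differs from compound 2 by hydrogen in place of methyl on an oxygen on an aromatic ring. Going by the values given here, no measured step touches this oxygen, and the single step known is itself within the scatter, so nothing here points in either direction in this assay. The expected step of a 1.0-fold higher number from compound 2 to compound 3 (0.01 log units; within the scatter) is therefore none beyond the scatter. Compound 3 is estimated at 300 nM in this assay, with a range from 100 nM to 900 nM.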

Compound 3, inhibition constant: 10000 nM
Compound 3: middle estimate off by 33-fold (1.52 log units), on the low side, and the stated range ends below it.
By their numbers in this assay, from the lowest: compounds 1 and 2 (each within the scatter of the next); then compound 3.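

In this assay this position does not accept every group alike: trifluoromethyl and methoxy stay within the scatter of each other, but hydroxy falls well away from both, with a 34-fold higher number from compound 2 to compound 3 (1.54 log units; beyond the scatter) and a 60-fold higher number from compound 1 to compound 3 (1.78 log units; beyond the scatter). Removing only the methyl from the oxygen is enough to produce the large step, which the earlier pair gave no hint of. The data shown offer no explanation for this drop.

Open, on these data alone, is whether an amine or a carboxylic acid in the same place would show a similar step. Also open, as far as these compounds go, is whether a longer ether such as ethoxy stays close to compound 2.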